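A few compounds are considered here, and "the series" means these few. Any claim that something is new, unique, unknown or untested is made for them only; others in the source may bear on it.

Compound 1 `Fc1ccc(-n2cc(COc3ccccc3-c3nc4ccccc4s3)nn2)cc1`: 18900 nM
Compound 2 `COc1cc(-c2cc(COc3ccccc3-c3nc4ccccc4s3)on2)cc(OC)c1OC`: 17500 nM

In a functional assay on COLO 205 cells (Homo sapiens) for cytotoxicity, read by MTT assay, with a stated time of 24 h (on this read-out lower numbers stand for stronger inhibition and higher numbers for weaker inhibition), compound 1 gives 18900 nM, the higher of the two numbers shown, yet the gap to compound 2 lies within the scatter, since compound 2 gives 17500 nM. Compound 3 `c1ccc(-n2cc(COc3ccccc3-c3nc4ccccc4s3)nn2)cc1` differs from compound 1 by hydrogen in place of fluoro on an aromatic carbon. Among the compounds with values here, no pair of measured compounds shows this change, so the expectation rests on its small size: the step from compound 1 to compound 3 is expected to be a 1.0-fold higher number from compound 1 to compound 3 (0.00 log units; within the scatter), that is, nothing beyond the scatter in either direction. Compound 3 is therefore estimated at 19000 nM, with a range from 8000 nM to 45000 nM.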

Compound 3, half-maximal inhibitory concentration: 16600 nM
Estimate against measurement, compound 3: 1.1-fold (0.06 log units) above, within the range that was stated.
By their numbers in this assay, from the lowest: compounds 3, 2 and 1 (each within the scatter of the next).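

Within the data shown here, the first single-place comparison, in this assay, replaces 4-fluorophenyl with phenyl and gives a 1.1-fold lower number from compound 1 to compound 3 (0.06 log units; within the scatter). At this position on the six-membered aromatic ring, the fluoro is therefore not needed to retain the cytotoxicity seen with compound 1. No measured evidence bears on the reason for this result. The compounds shown leave open whether an amine or a carboxylic acid on that same aromatic carbon would shift the number beyond the scatter. They also leave open whether changes elsewhere on the shared core would do so.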